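Trading the thiophene hydrazone for an open-chain ketone hydrazone

A few compounds are considered here, and "the series" means these few. Any claim that something is new, unique, unknown or untested is made for them only; others in the source may bear on it.

Compound 1 `COc1cccc(-c2csc(N/N=C3\CCC(C)C3)n2)c1`: 1450 nM
Compound 2 `CCC/C(C)=N/Nc1nc(-c2cccc(OC)c2)cs1`: 1310 nM
Compound 3 `COc1cccc(-c2csc(N/N=C/c3cccs3)n2)c1`: 458 nM

In an assay on isolated protein for inhibition of Amine oxidase [flavin-containing] A (Homo sapiens), read by fluorescence (a lower number here means a stronger inhibitor, a higher number a weaker inhibitor), compound 3 gives the lowest of the three numbers; compound 2 sits nearest, and compound 1 furthest, both beyond the scatter. Compound 4 `CCC(CC)=NNc1nc(-c2cccc(OC)c2)cs1` differs from compound 3 by a group of 6 heavy atoms (5 carbon, 1 nitrogen; no ring) in place of a group of 7 heavy atoms (5 carbon, 1 nitrogen, 1 sulfur; one five-membered aromatic ring with 1 hetero atom), on a nitrogen on an aromatic ring. The step from an open-chain group to the thiophene ring is the one already seen: a 2.9-fold lower number from compound 2 to compound 3 (0.46 log units; beyond the scatter) and, from the carbocyclic ring, a 3.2-fold lower number from compound 1 to compound 3 (0.50 log units; beyond the scatter); by contrast a 1.1-fold lower number from compound 1 to compound 2 (0.04 log units; within the scatter). Compound 4 undoes that change, so an increase beyond the scatter is expected, roughly mirroring the step to compound 3; the expected step is a 2.8-fold higher number from compound 3 to compound 4 (0.45 log units; beyond the scatter). Compound 4 is therefore estimated at 1300 nM, with a range from 600 nM to 2800 nM.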

Compound 4, half-maximal inhibitory concentration: 824 nM
Beside the measured number, compound 4's estimate is 1.6-fold (0.20 log units) above it, and the stated range covers the measured number.
By their numbers in this assay, from the lowest: compounds 3, 4, 2 and 1 (each within the scatter of the next, the first and the last beyond it).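

In this assay, the open-chain group of compound 4 cannot be told apart from the five-membered aromatic ring with 1 hetero atom (a 1.8-fold higher number from compound 3 to compound 4 (0.26 log units; within the scatter)). Compound 4 also stays level with the other two non-aromatic groups (a 1.6-fold lower number from compound 2 to compound 4 (0.20 log units; within the scatter); a 1.8-fold lower number from compound 1 to compound 4 (0.25 log units; within the scatter)), so the clear gap of compound 3 over compound 1 and compound 2 does not extend to every open-chain group at this nitrogen. No evidence at hand accounts for this.

As far as these compounds go, whether an amine or a carboxylic acid on the open chain, or a longer chain, would move the number stays open. So does whether a phenyl ring would match the five-membered aromatic ring.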